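From Bromo to Trifluoromethoxy: Expecting Tolerance Again

The compounds below may be only part of what the source reports. "The series", "measured", "known", "first", "only" and "open" are said of these compounds alone.

Compound 1, `O=c1[nH]c(=O)n([C@H]2C[C@H](O)[C@@H](CO)O2)cc1-c1cn(-c2ccc(Cl)cc2)nn1`, was tested in an ADME assay on HEL cells (Homo sapiens) for cytotoxicity, read by cell counting, with a stated time of 3 days; a lower number here means that less compound is tolerated, a higher number that more compound is tolerated. For compound 1 the result is only a limit of the assay, > 240000 nM. Compound 2, `O=c1[nH]c(=O)n([C@H]2C[C@H](O)[C@@H](CO)O2)cc1-c1cn(-c2ccc(Br)cc2)nn1`, carries bromo in place of chloro on an aromatic carbon. For compound 2 the result is again only a limit, >= 44000 nM. The step that the two limits leave unreadable from compound 1 to compound 2 therefore cannot be read, since both ends are limits, as the limit of > 240000 nM in this assay, at which 1 of the 2 values shown sits, and the limit of >= 44000 nM in this assay, at which 1 of the 2 values shown sits, show. So compound 2 stands at a limit rather than at a measured number, and the one further value known is also a limit.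

Compound 3, `O=c1[nH]c(=O)n([C@H]2C[C@H](O)[C@@H](CO)O2)cc1-c1cn(-c2ccc(OC(F)(F)F)cc2)nn1`, differs from compound 2 in one place: trifluoromethoxy in place of bromo on an aromatic carbon. For the measured compounds named here, no measured step here tells how this change acts, and the only step known, from the chloro to the bromo compound, is itself unreadable. The expectation for compound 3 is therefore simply that it is tolerated much like its two relatives, so compound 3 is estimated at 150000 nM, within a range from 40000 nM to 500000 nM. This estimate means a step that the limit leaves unreadable from compound 2 to compound 3, which is expected to be no real change and most likely again a limit.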

Compound 3, minimum cytotoxic concentration: > 220000 nM
Compound 3: no number, only a limit; the forecaster's own chance of this, stated with the estimate: 80%; middle value at least 1.4-fold (0.16 log units) away from the limit.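

Compound 3 gives only a limit of the assay, > 220000 nM. With limits at both ends, the steps to compound 3 from compound 1 and from compound 2 cannot be read. The compounds shown leave open whether the chloro, bromo and trifluoromethoxy groups make any real difference in this assay, and at what concentration each compound stops being tolerated.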